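Acetyl in place of the carbamate chain on the shared core

The source may report more compounds than this note shows. Statements on the series, on what has been measured and on what is new or still open speak of the compounds shown alone.

Three measured compounds share the core of compound 1, `CC1=C(N2CC2)C(=O)C(CC(C)OC(N)=O)=C(N2CC2)C1=O`. In a functional assay on L1210 cells (Mus musculus), with a stated time of 1 days (on this read-out higher numbers stand for higher potency (the scale is a negative logarithm) and lower numbers for lower potency), compound 1 gives 5.18, the highest of the three numbers. Compound 2, `COCCC1=C(N2CC2)C(=O)C(CCOC)=C(N2CC2)C1=O`, gives 4.71 in this assay, a number lower than that of compound 1 by more than the scatter. Compound 3, `CN(C)C(=O)OCCC1=C(N2CC2)C(=O)C(CCOC(=O)N(C)C)=C(N2CC2)C1=O`, gives 4.62 in this assay, the furthest from compound 1, again beyond the scatter.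

Compound 4, `CC(=O)C1=C(N2CC2)C(=O)C(C)=C(N2CC2)C1=O`, has not been measured. Relative to compound 1 it carries the change (a group of 3 heavy atoms (2 carbon, 1 oxygen; no ring) in place of a group of 7 heavy atoms (4 carbon, 1 nitrogen, 2 oxygen; no ring), on a double-bonded ring carbon). For the measured compounds named here, the entering acetyl is small next to the leaving group of seven heavy atoms, and no measured pair in the set shows the effect of such a change, so the size of the step is uncertain. Because compound 1 stands at 5.18 and the other two compounds fall below it, the expected step of a number 0.18 log units lower from compound 1 to compound 4 (within the scatter) is taken as none beyond the scatter, with a lean toward a lower number. Compound 4 is therefore estimated at 5 in this assay, within a range from 4.4 to 5.6.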

Compound 4, logarithm of the reciprocal of the active concentration, log(1/C): 3.48
Beside the measured number, compound 4's estimate is 1.52 log units above it, and the stated range ends above it.
By their numbers in this assay, from the lowest: compound 4; then compounds 3 and 2 (each within the scatter of the next); then compound 1.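

In this assay, acetyl in place of the group of 7 heavy atoms on the double-bonded ring carbon gives a number 1.70 log units lower from compound 1 to compound 4 (beyond the scatter), the first step read at this position, and a large one. The position is therefore not indifferent to what it carries, at least across this exchange, in which the leaving group has 1 hydrogen-bond donor and the entering acetyl has 0 hydrogen-bond donors and is also the smaller group. Nothing here gives a cause for the step or separates the change in size from the change in donors.

Still open, from the compounds shown here alone, is whether chain length or the carbamate end matters more at this carbon. A longer chain ending in an amine or a carboxylic acid, or a plain propyl chain, would test how much of the step belongs to each.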